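The source may hold more compounds than are shown below. What is called first, only, known or untested is meant among the compounds shown, and "the series" means these compounds.

Compound 1 `CC#CCC(O)(c1ccc(N2CCN(S(=O)(=O)c3ccc(N)nc3)C[C@@H]2C#CC)cc1)C(F)(F)F` is measured in an assay on isolated protein for inhibition of glucokinase regulatory protein (Homo sapiens), read by AlphaScreen, with stated times of 20 min and 4 h (a lower number here means a stronger inhibitor, a higher number a weaker inhibitor), and gives 5 nM. Compound 2 `CC#C[C@H]1CN(S(=O)(=O)c2ccc(N)nc2)CCN1c1ncc(C(O)(C(F)(F)F)C(F)(F)F)cn1` gives 10 nM in this assay, and the gap between these two lies within the usual scatter, so neither number can be ranked ahead of the other. Compound 3 `CC#C[C@H]1CN(S(=O)(=O)c2ccc(N)nc2)CCN1c1ccc([S+](C)[O-])cc1` has not been measured. It differs from compound 1 by a group of 3 heavy atoms (1 carbon, 1 oxygen, 1 sulfur; no ring) in place of a group of 10 heavy atoms (6 carbon, 1 oxygen, 3 fluorine; no ring), on an aromatic carbon. For the measured compounds named here, no step between measured compounds tests this change. A large group leaving is expected to cost potency, a step of a 60-fold higher number from compound 1 to compound 3 (1.78 log units; beyond the scatter) from compound 1 to compound 3. Compound 3 is therefore estimated at 300 nM, with a range from 60 nM to 2000 nM.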

Compound 3, half-maximal inhibitory concentration: 3360 nM
Estimate against measurement, compound 3: 11-fold (1.05 log units) below, and the stated range ends below it.
By their numbers in this assay, from the lowest: compounds 1 and 2 (each within the scatter of the next); then compound 3.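

In this assay, the group of 3 heavy atoms in place of the group of 10 heavy atoms gives a 670-fold higher number from compound 1 to compound 3 (2.83 log units; beyond the scatter) and this is the first single change shown at this aromatic carbon. It shows that potency depends strongly on what this position carries, which the earlier pair could not show, since compound 1 and compound 2 differ in more than one place. No measurement here accounts for the size of this loss.

The compounds shown leave open whether a shorter chain keeping the hydroxyl and trifluoromethyl groups would recover potency. They also leave open how an amine or a carboxylic acid would fare at this position.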